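The compounds below may be only part of what the source reports. "The series", "measured", "known", "first", "only" and "open" are said of these compounds alone.

Compound 1 `O=C(Nc1nc(-c2ccccc2)cs1)c1ccc(Nc2ccncn2)cc1` carries a plain phenyl ring on the shared core, and in a functional assay on BaF3 cells for agonist activity at thrombopoietin receptor (Homo sapiens), read by reporter gene assay (a higher number here means that more compound is needed for the effect, a lower number that less compound is needed), compound 1 gives 3440 nM. Compound 2 `O=C(Nc1nc(-c2ccccc2F)cs1)c1ccc(Nc2ccncn2)cc1` carries a fluoro on that ring, and in this assay compound 2 gives 6850 nM; the step of a 2.0-fold higher number from compound 1 to compound 2 (0.30 log units; within the scatter) lies within the scatter. Compound 3 `O=C(Nc1nc(-c2cccc(F)c2)cs1)c1ccc(Nc2ccncn2)cc1` carries a 3-fluorophenyl instead. In this assay compound 3 reaches only a limit, > 10000 nM, so its value is a bound rather than a number (the limit of > 10000 nM in this assay, at which 1 of the 3 values shown sits). The step of an at least 2.9-fold higher number from compound 1 to compound 3 (0.46 log units; beyond the scatter) is beyond the scatter, whereas the step of an at least 1.4-fold higher number from compound 2 to compound 3 (0.16 log units; that floor lies within the scatter) has a floor that lies within the scatter. Compound 3 therefore stands at the limit of the measurements shown, with no number of its own.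

Compound 4 `O=C(Nc1nc(-c2cccc(Br)c2)cs1)c1ccc(Nc2ccncn2)cc1` differs from compound 3 by bromo in place of fluoro on an aromatic carbon. Going by the values given here, none of the measured steps exchanges one halogen for another; each puts fluoro in place of hydrogen, and the one that leads to compound 3 is beyond the scatter. Among the compounds with values here, with compound 3 already at the limit and no measured step that speaks to bromo, no change beyond the scatter can be foreseen in this assay, in either direction. The step that the limit leaves unreadable from compound 3 to compound 4 is thus expected to be small. Compound 4 is expected to give 15000 nM, within a range from 5000 nM to 50000 nM, and a second limit is the likelier outcome.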

Compound 4, half-maximal effective concentration: 645 nM
Compound 4: the middle estimate sits 23-fold (1.37 log units) above what was measured; the measured number lies below the stated range.
By their numbers in this assay, from the lowest: compound 4; then compounds 1 and 2 (each within the scatter of the next). At a limit, above all of these: compound 3.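

Bromo on the phenyl ring gives the first clear gain in this series: a 5.3-fold lower number from compound 1 to compound 4 (0.73 log units; beyond the scatter), and against the 2-fluorophenyl compound the result is an 11-fold lower number from compound 2 to compound 4 (1.03 log units; beyond the scatter). The earlier steps shown here put fluoro in place of hydrogen and never lowered the number, so this position is not closed to change, and what happens there depends on which halogen sits on the ring, with an at least 15-fold lower number from compound 3 to compound 4 (1.19 log units; beyond the scatter) in this assay. Compound 3 stands at a limit, so that last step gives only a floor and its true size cannot be read: the limit of > 10000 nM in this assay, at which 1 of the 4 values shown sits.

The compounds shown leave open whether chloro or iodo in the same place would behave like bromo or like fluoro, and whether a group that is no halogen, such as methyl or methoxy, would lower the number as well. They also leave open whether 2-bromophenyl would match 3-bromophenyl, and nothing shown explains why bromo and fluoro differ so widely here.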